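Nucleoside sultam series: amine substituent and cytotoxicity

A few compounds are considered here, and "the series" means these few. Any claim that something is new, unique, unknown or untested is made for them only; others in the source may bear on it.

Compound 1 `CCOC(=O)NC(=O)NC1=CS(=O)(=O)O[C@@]12[C@@H](CO[Si](C)(C)C(C)(C)C)O[C@@H](n1cc(C)c(=O)n(C)c1=O)[C@@H]2O[Si](C)(C)C(C)(C)C` in a functional assay on CCRF-CEM cells (Homo sapiens); on this read-out lower numbers stand for higher toxicity in this test and higher numbers for lower toxicity in this test: compound 1 gives 3000 nM.
Compound 2 `Cc1cn([C@@H]2O[C@H](CO[Si](C)(C)C(C)(C)C)[C@@]3(OS(=O)(=O)C=C3NC(=O)c3ccccc3)[C@H]2O[Si](C)(C)C(C)(C)C)c(=O)n(C)c1=O` in this assay: compound 2 gives 4910 nM.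
Compound 3 `COC(=O)CCNC1=CS(=O)(=O)O[C@@]12[C@@H](CO[Si](C)(C)C(C)(C)C)O[C@@H](n1cc(C)c(=O)n(C)c1=O)[C@@H]2O[Si](C)(C)C(C)(C)C` in this assay: compound 3 gives only a limit, > 250000 nM.

Compound 3 stands at the limit of this assay, with no number of its own (the limit of > 250000 nM in this assay, at which 1 of the 3 values shown sits). Both steps into it are large: an at least 83-fold higher number from compound 1 to compound 3 (1.92 log units; beyond the scatter) and an at least 50-fold higher number from compound 2 to compound 3 (1.70 log units; beyond the scatter). Compound 4 `Cc1cn([C@@H]2O[C@H](CO[Si](C)(C)C(C)(C)C)[C@@]3(OS(=O)(=O)C=C3NCC(=O)O)[C@H]2O[Si](C)(C)C(C)(C)C)c(=O)n(C)c1=O` keeps the amine of compound 3 and changes the chain: carboxy in place of (methoxycarbonyl)methyl on a saturated chain carbon bound to an amine nitrogen. Among the compounds with values here, no measured step covers this change, and both measured steps concern the amine substituent as a whole. With compound 3 at a limit, compound 4 is expected to stay at or near that limit, so a number no higher from compound 3 to compound 4 (the limit leaves the size open) is estimated. For compound 4 the estimate is 250000 nM, between 50000 nM and 1000000 nM.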

Compound 4, half-maximal cytotoxic concentration: 65000 nM
The estimate for compound 4 lay 3.8-fold (0.59 log units) above the measured number; low and high end bracket the measured number.
By their numbers in this assay, from the lowest: compounds 1 and 2 (each within the scatter of the next); then compound 4. At a limit, above all of these: compound 3.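

Carboxy in place of (methoxycarbonyl)methyl on a saturated chain carbon bound to an amine nitrogen gives an at least 3.8-fold lower number from compound 3 to compound 4 (0.58 log units; beyond the scatter) in this assay, so a saturated chain on the amine need not sit at the top of the scale. Going by these compounds, compound 3 holds only a limit, and the full size of this step stays open: the limit of > 250000 nM in this assay, at which 1 of the 4 values shown sits. The chain still gives higher numbers than the carbonyl-bound substituents, with a 13-fold higher number from compound 2 to compound 4 (1.12 log units; beyond the scatter) and a 22-fold higher number from compound 1 to compound 4 (1.34 log units; beyond the scatter).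

Chain length and end group change together in this step. A 2-carboxyethyl chain or a (methoxycarbonyl)methyl chain on the amine would separate the two.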